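From tert-Butoxycarbonyl to Formyl at the Ring Nitrogen

The source may hold more compounds than are shown below. What is called first, only, known or untested is meant among the compounds shown, and "the series" means these compounds.

Compound 1 `CC(C)(C)OC(=O)N1CCC[C@H]1COCCCCCC/C=C/c1ccc(-c2ccccc2)cc1`: > 100000 nM
Compound 2 `CC(C)(C)OC(=O)N1CCC[C@H]1COCCCCCC/C=C/c1ccc(Oc2ccccc2)cc1`: 63300 nM

Of the compounds shown here, two have been measured in a functional assay on BXPC-3 cells (Homo sapiens) for inhibition, read by XTT assay, with a stated time of 72 h; on this read-out higher numbers stand for weaker inhibition and lower numbers for stronger inhibition. Compound 1 `CC(C)(C)OC(=O)N1CCC[C@H]1COCCCCCC/C=C/c1ccc(-c2ccccc2)cc1` reaches only the limit of the assay, > 100000 nM, which is a limit and not a number (the limit of > 100000 nM in this assay, at which 1 of the 2 values shown sits). Compound 2 `CC(C)(C)OC(=O)N1CCC[C@H]1COCCCCCC/C=C/c1ccc(Oc2ccccc2)cc1` gives 63300 nM, the only number shown; the change an at least 1.5-fold lower number from compound 1 to compound 2 (0.19 log units; that floor lies within the scatter) is the sole measured step, and it concerns the aromatic substituent, not the carbamate.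

Compound 3 `O=CN1CCC[C@H]1COCCCCCC/C=C/c1ccc(Oc2ccccc2)cc1` differs from compound 2 by hydrogen in place of tert-butoxy on a carbonyl carbon. Among the compounds with values here, no measured step touches this part of the molecule, so the single step from compound 1 to compound 2 offers no guidance on how large this change should be, or in which direction. With nothing to anchor it, the step of a 1.3-fold higher number from compound 2 to compound 3 (0.10 log units; within the scatter) is expected to stay close to the scatter, and compound 3 is estimated at 80000 nM, within a range from 25000 nM to 250000 nM, with a real chance that this assay reports only a limit.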

Compound 3, half-maximal inhibitory concentration: 46700 nM
Beside the measured number, compound 3's estimate is 1.7-fold (0.23 log units) above it; measured number inside the range.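

In this assay, within the data shown here, the earlier compounds offered a single step at the aromatic substituent, so this is the first reading at the carbonyl carbon on the ring nitrogen. Replacing tert-butoxy, with its 5 heavy atoms, by a lone hydrogen gives a 1.4-fold lower number from compound 2 to compound 3 (0.13 log units; within the scatter), which shows that this whole group can be exchanged at this position while the two values stay within the scatter. Compound 1 remains the only compound shown with a limit, which is not a number: the limit of > 100000 nM in this assay, at which 1 of the 3 values shown sits.

The compounds shown leave open whether any group on this carbonyl carbon would move the number beyond the scatter, for instance an amine or a carboxylic acid in place of the hydrogen, or whether a ring nitrogen with no carbonyl at all would do so. Going by these compounds, the step from phenyl to phenoxy was read only with tert-butoxycarbonyl on the ring nitrogen, so it also remains open how the aromatic substituent behaves with formyl there, and what a longer chain would do.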